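This account rests on a few compounds, and the source may have more. Where it says the series, first, only, none or still open, it means among the compounds named here.

Both measured compounds share one core and differ in the side chain. In a functional assay on UACC-257 cells (Homo sapiens) for inhibition, read by sulforhodamine B assay, with a stated time of 48 h (a lower number here means a stronger inhibitor of growth, a higher number a weaker inhibitor of growth), compound 1 `CN1CCCN(CCNc2nccc(-c3c(-c4cccc(O)c4)nc4sccn34)n2)S1(=O)=O` gives > 100000 nM, which is a limit of the assay. Compound 2 `O=S(=O)(NCCCNc1nccc(-c2c(-c3cccc(O)c3)nc3sccn23)n1)c1cccc(F)c1` gives > 100000 nM, which is also a limit. Among the measured compounds shown here, the only measured step, a step that the two limits leave unreadable from compound 1 to compound 2, therefore offers no size to carry forward. What remains is the limit of > 100000 nM in this assay, at which 2 of the 2 values shown sit.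

The unmeasured compound 3 `O=S(=O)(NCCNc1nccc(-c2c(-c3cccc(O)c3)nc3sccn23)n1)c1ccc(F)cc1` differs from compound 2 as follows: ((4-fluorophenyl)sulfonyl)amino in place of (((3-fluorophenyl)sulfonyl)amino)methyl on a saturated chain carbon, two bonds along the chain from a nitrogen on an aromatic ring. In words, this places ((4-fluorophenyl)sulfonyl)amino in place of (((3-fluorophenyl)sulfonyl)amino)methyl on a saturated chain carbon, two bonds along the chain from a nitrogen on an aromatic ring.

With no readable step to draw on, no change beyond the scatter is expected in this assay, in either direction. The expected step is a number no higher from compound 2 to compound 3 (the limit leaves the size open). For compound 3 the estimated value is 100000 nM, with an expected range from 40000 nM to 200000 nM.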

Compound 3, concentration for total growth inhibition: 16500 nM
Beside the measured number, compound 3's estimate is 6.1-fold (0.78 log units) above it; the measured number lies below the stated range.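

In this assay, this chain position proves able to respond to change: ((4-fluorophenyl)sulfonyl)amino in place of (((3-fluorophenyl)sulfonyl)amino)methyl gives an at least 6.0-fold lower number from compound 2 to compound 3 (0.78 log units; beyond the scatter), and the same group set against the ring-bearing side chain of compound 1 gives an at least 6.0-fold lower number from compound 1 to compound 3 (0.78 log units; beyond the scatter). The earlier step between compound 1 and compound 2 cannot be read, so it could not show this. Both new steps give only a minimum size, because their starting values are limits of the assay: the limit of > 100000 nM in this assay, at which 2 of the 3 values shown sit.

The change from compound 2 to compound 3 does two things at once, dropping the methyl and moving the fluorine from the 3-fluorophenyl to the 4-fluorophenyl form, and the compounds shown do not separate these two. Also open, as far as these compounds go, is how ((3-fluorophenyl)sulfonyl)amino or (((4-fluorophenyl)sulfonyl)amino)methyl would read at this position, and how a simple amine would compare there.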